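Replacing 3-methylphenyl with 4-nitrophenyl: a weak starting point

The compounds below may be only part of what the source reports. "The series", "measured", "known", "first", "only" and "open" are said of these compounds alone.

In a functional assay on HCT-116 cells (Homo sapiens) for antiproliferative activity, read by MTT assay, with a stated time of 48 h (on this read-out higher numbers stand for weaker inhibition and lower numbers for stronger inhibition), compound 1 `N#CC1=C(N)Oc2c(c3nc4ccccc4nc3c3ccccc23)C12C(=O)N(Cc1cnnn1-c1ccc(N)cc1)c1ccccc12` gives 45200 nM. Compound 2 `Cc1cccc(-n2nncc2CN2C(=O)C3(C(C#N)=C(N)Oc4c(N)cc5nc6ccccc6nc5c43)c3ccccc32)c1` is recorded only as a limit of the assay, > 50000 nM, so no number stands for it (the limit of > 50000 nM in this assay, at which 1 of the 2 values shown sits). Both compounds thus lie at the weak end of the range shown here. Compound 3 `N#CC1=C(N)Oc2c(N)cc3nc4ccccc4nc3c2C12C(=O)N(Cc1cnnn1-c1ccc([N+](=O)[O-])cc1)c1ccccc12` differs from compound 2 in one place, (4-nitrophenyl in place of 3-methylphenyl on an aromatic nitrogen). Within the data shown here, no step between two measured compounds is available to calibrate such a change, and compound 1 is not a single-point neighbour of either compound 2 or compound 3. The author therefore expects an at least 1.1-fold lower number from compound 2 to compound 3 (0.04 log units; that floor lies within the scatter) to amount to no change beyond the usual scatter, with compound 3 most likely remaining close to where compound 2 stands. On that basis compound 3 is estimated at 45000 nM, within a range from 18000 nM to 110000 nM.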

Compound 3, half-maximal inhibitory concentration: > 50000 nM
Compound 3: only a limit was reported; the forecaster's own chance of this, stated with the estimate: 55%; at least 1.1-fold (0.04 log units) between middle value and limit.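

Compound 3 is recorded only as a limit, as compound 2 is, so no step between compound 2 and compound 3 can be read: the limit of > 50000 nM in this assay, at which 2 of the 3 values shown sit.

From the compounds shown here alone, whether 4-nitrophenyl in place of 3-methylphenyl on the aromatic nitrogen changes activity in this assay, and by how much, stays open.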